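Changing the ring on compound 3's amide nitrogen

The source may report more compounds than this note shows. Statements on the series, on what has been measured and on what is new or still open speak of the compounds shown alone.

Compound 1 `CCn1cc(C(=O)C(=O)Nc2ccnc(OC)c2)c2ccccc21`: 4180 nM
Compound 2 `COCCn1cc(C(=O)C(=O)Nc2ccncc2)c2ccccc21`: > 10000 nM (a limit of the assay)
Compound 3 `COCCn1cc(C(=O)C(=O)Nc2cnc(OC)nc2)c2ccccc21`: 55 nM

Among the compounds with values here, in a functional assay on FaDu cells (Homo sapiens) for cytotoxicity, read by MTT assay, with a stated time of 72 h (a higher number here means that more compound is tolerated, a lower number that less compound is tolerated), compound 3 gives 55 nM, the lowest number measured so far. Compound 1 gives 4180 nM, and the gap to compound 3 lies beyond the scatter. The value of compound 2, > 10000 nM, is a limit of the assay.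

Compound 4 `COCCn1cc(C(=O)C(=O)Nc2ccnc(OC)c2)c2ccccc21` changes only the ring on the amide-type nitrogen of compound 3: 2-methoxypyridin-4-yl in place of 2-methoxypyrimidin-5-yl on an amide-type nitrogen. Within the data shown here, the one measured step that changes this ring, an at least 180-fold lower number from compound 2 to compound 3 (2.25 log units; beyond the scatter), was large and beyond the scatter. It also left a pyridine-type ring behind in favour of 2-methoxypyrimidin-5-yl, and the new change runs the other way. Compound 1 carries the same 2-methoxypyridin-4-yl and gives 4180 nM. A large step to a higher number in this assay is therefore expected, a 27-fold higher number from compound 3 to compound 4 (1.44 log units; beyond the scatter). The estimated value for compound 4 is 1500 nM, with an expected range from 200 nM to 8000 nM.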

Compound 4, concentration lethal to 50% of the cells: 235 nM
Compound 4: the middle estimate sits 6.4-fold (0.81 log units) above what was measured, and the stated range covers the measured number.
By their numbers in this assay, from the lowest: compound 3; then compound 4; then compound 1. At a limit, above all of these: compound 2.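

Changing the ring on the amide nitrogen matters far less here than the earlier step suggested: in this assay, the swap gives a 4.3-fold higher number from compound 3 to compound 4 (0.63 log units; beyond the scatter). The methoxy on the ring carries much of the difference, with an at least 42-fold lower number from compound 2 to compound 4 (1.62 log units; beyond the scatter), though this step starts from a limit of the assay: the limit of > 10000 nM in this assay, at which 1 of the 4 values shown sits. The methoxy on the saturated chain also counts, with an 18-fold lower number from compound 1 to compound 4 (1.25 log units; beyond the scatter).

Still open, on these data alone, is how an amine or a longer alkoxy group would behave on the ring in place of methoxy. A carboxylic acid at the end of the chain is equally untested among these compounds.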